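Swapping an imidazole for a dimethylamino group on a pyrrolidinone chain

The compounds below may be only part of what the source reports. "The series", "measured", "known", "first", "only" and "open" are said of these compounds alone.

Measured so far:
compound 1, `CC(C#CCn1ccnc1)N1CCCC1=O`, 45 mg/kg
compound 2, `CC(C#CCN(C)C)N1CCCC1=O`, > 100 mg/kg
compound 3, `CC1CCC(=O)N1CC#CCn1ccnc1`, 20.9 mg/kg

In a functional assay on the whole organism for antagonist activity, with Mus musculus as the target (on this read-out lower numbers stand for an effect already at smaller amounts and higher numbers for an effect only at larger amounts of compound), compound 1 gives 45 mg/kg. Among the measured compounds shown here, for compound 2 the assay reports only a limit, > 100 mg/kg, and this is the one value among the three that sits at the limit of > 100 mg/kg in this assay, at which 1 of the 3 values shown sits. Compound 3 is the lowest of the two real numbers, and in this assay compound 3 gives 20.9 mg/kg; compound 3 and compound 1 share the same atoms joined differently, and the difference between the two cores is not broken down here.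

One structural change appears twice. Between compound 1 and compound 2 it is dimethylamino in place of 1H-imidazol-1-yl on a saturated chain carbon bound to a triple-bonded carbon, and it gave an at least 2.2-fold higher number from compound 1 to compound 2 (0.34 log units; beyond the scatter), a step that reaches the limit. Compound 4, `CC1CCC(=O)N1CC#CCN(C)C`, is not yet measured; it differs from compound 3 by dimethylamino in place of 1H-imidazol-1-yl on a saturated chain carbon bound to a triple-bonded carbon, the same change at the same place.

Since compound 3 starts at 20.9 mg/kg and the same change on compound 1 gave an at least 2.2-fold higher number from compound 1 to compound 2 (0.34 log units; beyond the scatter), compound 4 is expected to need a larger dose, a step estimated as a 3.8-fold higher number from compound 3 to compound 4 (0.58 log units; beyond the scatter). The estimated value for compound 4 in this assay is 80 mg/kg, between 35 mg/kg and 200 mg/kg.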

Compound 4, dose for half-maximal effect: > 100 mg/kg
Compound 4 ended at the assay's limit (the forecaster's own chance of this, stated with the estimate: 45%); middle value at least 1.2-fold (0.09 log units) from the limit.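

In this assay compound 4 gives > 100 mg/kg, which is a limit of the assay and not an exact number. Putting dimethylamino in place of 1H-imidazol-1-yl on the core of compound 3 gave an at least 4.7-fold higher number from compound 3 to compound 4 (0.67 log units; beyond the scatter), so the change pushed the number upward on both cores, and the two steps can be compared only this far: the same change on two cores in this assay, an at least 2.2-fold higher number (0.34 log units; beyond the scatter) from compound 1 to compound 2 and an at least 4.7-fold higher number (0.67 log units; beyond the scatter) from compound 3 to compound 4; the limit leaves it open whether they differ This shows that the direction of the change carried over from the core of compound 1 to the core of compound 3, but it does not give the true size of either step or show that the change costs the same on both cores.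

The compounds shown cannot say whether the upward step is specific to dimethylamino or would also appear with another amine, such as diethylamino. They also leave open whether the same direction would hold with a longer chain in place of the present one, or on any core beyond these two.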